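The source may hold more compounds than are shown below. What is called first, only, known or untested is meant among the compounds shown, and "the series" means these compounds.

Three compounds have so far been measured in a toxicity assay on THP-1 cells (Homo sapiens) for inhibition; on this read-out lower numbers stand for higher toxicity in this test and higher numbers for lower toxicity in this test:

Compound 1 `Cc1ccc(-c2cnc(NC(=O)c3ccc(F)cc3)n2C)cc1` gives 60000 nM.
Compound 2 `Cn1c(-c2ccc(F)cc2)cnc1NC(=O)c1ccc(F)cc1` gives > 100000 nM, which is a limit of the assay and not a number.
Compound 3 `COc1ccc(-c2cnc(NC(=O)c3ccccc3C)n2C)cc1` gives > 100000 nM, again a limit of the assay and not a number.

Compound 4 `COc1ccc(-c2cnc(NC(=O)c3ccccc3F)n2C)cc1` has not yet been measured in this assay. It differs from compound 3 by fluoro in place of methyl on an aromatic carbon. The same kind of change separates compound 1 from compound 2, namely (fluoro in place of methyl on an aromatic carbon). The surroundings are not identical, though: in the measured pair the place is para to a large group, whereas in compound 4 it is ortho to a large group, so this is the same kind of change and not the same change. The measured step reads an at least 1.6-fold higher number from compound 1 to compound 2 (0.22 log units; that floor lies within the scatter). Because (the limit of > 100000 nM in this assay, at which 2 of the 3 values shown sit), the true size of that step cannot be pinned down more closely. How the core of compound 1 and the core of compound 3 differ is not broken down here.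

For compound 4 the expected step in this assay is a step that the limit leaves unreadable from compound 3 to compound 4, resting on the measured step of an at least 1.6-fold higher number from compound 1 to compound 2 (0.22 log units; that floor lies within the scatter) and on the value of compound 3, > 100000 nM, which is already a limit. Compound 4 is therefore expected to give about 150000 nM in this assay, most probably reported once more as a limit, with a plausible range from 60000 nM to 400000 nM.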

Compound 4, half-maximal cytotoxic concentration: > 100000 nM
Compound 4 was reported as a limit; the forecaster's own chance of this, stated with the estimate: 75%; the middle value is on the limit's open side.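

No size can be read for the change from 2-methylphenyl in compound 3 to 2-fluorophenyl in compound 4, because neither compound gives a number, only a limit of the assay: the limit of > 100000 nM in this assay, at which 3 of the 4 values shown sit.

The compounds shown leave open where the true numbers of compound 2, compound 3 and compound 4 lie in this assay, and whether fluoro in place of methyl at this place changes the read-out at all.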